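This account rests on a few compounds, and the source may have more. Where it says the series, first, only, none or still open, it means among the compounds named here.

Measured so far:
- compound 1, `N#Cc1ccccc1-n1cc(-c2n[nH]c3cc(Cl)c(N[C@@H]4CCNC4)cc23)cn1` — in an assay on isolated protein for inhibition of tyrosine-protein kinase receptor UFO (Homo sapiens), with a stated time of 1.5 h (on this read-out lower numbers stand for stronger inhibition and higher numbers for weaker inhibition), compound 1 gives 3200 nM
- compound 2, `N#Cc1ccc(-n2cc(-c3n[nH]c4cc(Cl)c(N[C@@H]5CCNC5)cc34)cn2)cc1` — in this assay compound 2 gives 700 nM

Among the measured compounds shown here, compound 2 holds the lowest of the two numbers so far; the only neighbour is compound 1, and the step of a 4.6-fold lower number from compound 1 to compound 2 (0.66 log units; beyond the scatter) is beyond the scatter, so compound 2 is the stronger of the two.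

Compound 3, `COc1ccc(-n2cc(-c3n[nH]c4cc(Cl)c(N[C@@H]5CCNC5)cc34)cn2)cc1`, is the next member. The change from compound 2 is methoxy in place of cyano on an aromatic carbon. For the measured compounds named here, no measured step shows this change: the one step seen, from compound 1 to compound 2, moves the cyano group around the ring and keeps it, so it says nothing about replacing the nitrile by a methoxy group. Without a precedent, the working assumption is a small shift, somewhat toward weaker inhibition, hedged widely.

For compound 3 the estimate in this assay is 1500 nM, with a range from 400 nM to 5500 nM; this corresponds to an expected step of a 2.1-fold higher number from compound 2 to compound 3 (0.33 log units; beyond the scatter).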

Compound 3, half-maximal inhibitory concentration: 300 nM
Compound 3: the middle estimate sits 5.0-fold (0.70 log units) above what was measured; measured number below the stated range.
By their numbers in this assay, from the lowest: compound 3; then compound 2; then compound 1.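

At the aromatic carbon para to a large group, the nitrile is not needed to reach the number of compound 2 in this assay: methoxy in place of cyano gives a 2.3-fold lower number from compound 2 to compound 3 (0.37 log units; beyond the scatter), a modest step beyond the scatter. The larger change, 4-methoxyphenyl in place of 2-cyanophenyl on the aromatic nitrogen, gives an 11-fold lower number from compound 1 to compound 3 (1.03 log units; beyond the scatter), which makes compound 3 the strongest of the three in this series. Nothing available explains why methoxy does better than cyano at this place.

Two groups at this place set no trend, so an amine, a carboxylic acid or a longer chain such as ethoxy could fall on either side of methoxy. As far as these compounds go, how methoxy behaves at the ring position that carries the nitrile in compound 1 also stays open.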